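The source may report more compounds than this note shows. Statements on the series, on what has been measured and on what is new or still open speak of the compounds shown alone.

Measured compounds:
compound 1 `COc1ccc(F)cc1CNCCCNc1ccnc2cc(Oc3ccc(F)cc3)ccc12`: 6600 nM
compound 2 `COc1ccc(F)cc1CNCCCNc1ccnc2cc(Oc3cccc(N(C)C)c3)ccc12`: 3300 nM
compound 3 `COc1cccc(CNCCCNc2ccnc3cc(Oc4cccc(N(C)C)c4)ccc23)c1O`: 7300 nM

All three values come from an ADME assay on HepG2 cells (Homo sapiens) for cytotoxicity, read by luminescence, CellTiter-Glo and ATP content, with a stated time of 72 h; on this read-out higher numbers stand for an effect only at larger amounts of compound and lower numbers for an effect already at smaller amounts. Compound 4 `COc1cccc(CNCCCNc2ccnc3cc(Oc4ccc(F)cc4)ccc23)c1O` has not been measured. It differs from compound 3 in one place: 4-fluorophenyl in place of 3-(dimethylamino)phenyl on an oxygen on an aromatic ring. The same change has been made once before, from compound 2 to compound 1: 4-fluorophenyl in place of 3-(dimethylamino)phenyl on an oxygen on an aromatic ring, and that step was a 2.0-fold higher number from compound 2 to compound 1 (0.30 log units; within the scatter). The place of the change is described in exactly the same words in both pairs, so this is the same change, made on a different core. The two cores differ as follows: 2-hydroxy-3-methoxyphenyl in place of 5-fluoro-2-methoxyphenyl on a saturated chain carbon bound to an amine nitrogen, a change that gave a 2.2-fold higher number from compound 2 to compound 3 (0.34 log units; beyond the scatter). Compound 3 carries the highest number of the three measured, although its gap to compound 1 is within the scatter.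

For compound 4 the step is expected to be about a 1.8-fold higher number from compound 3 to compound 4 (0.25 log units; within the scatter). Among the measured compounds shown here, this expectation rests on the single earlier example, compound 1 against compound 2, where the step was a 2.0-fold higher number from compound 2 to compound 1 (0.30 log units; within the scatter), and on compound 3 standing at 7300 nM as the starting point. For the measured compounds named here, since only one earlier example exists, the range is kept wide. Compound 4 is expected to give about 13000 nM, between 5000 nM and 32000 nM.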

Compound 4, half-maximal effective concentration: 11000 nM
For compound 4 the middle estimate is 1.2-fold (0.07 log units) above the measured one; measured number inside the range.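

In this assay, putting 4-fluorophenyl in place of 3-(dimethylamino)phenyl gave a 1.5-fold higher number from compound 3 to compound 4 (0.18 log units; within the scatter), and this step agrees with its earlier counterpart: the same change on two cores in this assay, a 2.0-fold higher number (0.30 log units; within the scatter) from compound 2 to compound 1 and a 1.5-fold higher number (0.18 log units; within the scatter) from compound 3 to compound 4, 1.3-fold (0.12 log units) apart, within the scatter of two such steps

The second change, 2-hydroxy-3-methoxyphenyl in place of 5-fluoro-2-methoxyphenyl, gave a 1.7-fold higher number from compound 1 to compound 4 (0.22 log units; within the scatter), and it also agrees with its counterpart: the same change on two cores in this assay, a 2.2-fold higher number (0.34 log units; beyond the scatter) from compound 2 to compound 3 and a 1.7-fold higher number (0.22 log units; within the scatter) from compound 1 to compound 4, 1.3-fold (0.12 log units) apart, within the scatter of two such steps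

So each change behaved alike on the two cores as far as this read-out can tell, but three of the four steps lie within the scatter, which leaves little room to see a real difference, and two cores cannot show that either change would carry over to a third.

The compounds shown leave open whether this agreement would hold with another group on the oxygen, such as cyclohexyl or a pyridine ring, or with a longer chain on the amine nitrogen. They also leave open how these changes would read in any assay other than this assay.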